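Side-chain swap at the assay limit

A few compounds are considered here, and "the series" means these few. Any claim that something is new, unique, unknown or untested is made for them only; others in the source may bear on it.

Measured in an ADME assay on Huh-7 cells (Homo sapiens) for cytotoxicity, with a stated time of 72 h; a lower number here means that less compound is tolerated, a higher number that more compound is tolerated:
- Compound 1 `CCC(C)CCn1nc(-c2cccs2)c(O)c(C2=NS(=O)(=O)c3cc(NS(C)(=O)=O)ccc3N2)c1=O`: > 1000 nM (a limit)
- Compound 2 `CS(=O)(=O)Nc1ccc2c(c1)S(=O)(=O)N=C(c1c(O)c(-c3cccs3)nn(CC3CCC3)c1=O)N2`: > 1000 nM (a limit)
- Compound 3 `COCCn1nc(-c2cccs2)c(O)c(C2=NS(=O)(=O)c3cc(NS(C)(=O)=O)ccc3N2)c1=O`: > 1000 nM (a limit)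

Compound 3 stands at > 1000 nM, which is a limit and not a number. The whole series shares this position, with the limit of > 1000 nM in this assay, at which 3 of the 3 values shown sit.

The next analogue is compound 4 `CC(C)Cn1nc(-c2cccs2)c(O)c(C2=NS(=O)(=O)c3cc(NS(C)(=O)=O)ccc3N2)c1=O`, and the change to it is isopropyl in place of methoxymethyl on a saturated chain carbon bound to an aromatic nitrogen. In words, isopropyl takes the place of methoxymethyl on a saturated chain carbon bound to an aromatic nitrogen. The same difference, cut one bond further out, reads 2-methoxyethyl to isobutyl.

For the measured compounds named here, three measured steps bear on this change by varying the same chain: a step that the two limits leave unreadable from compound 2 to compound 3, a step that the two limits leave unreadable from compound 1 to compound 3 and a step that the two limits leave unreadable from compound 1 to compound 2. None of them gives a size that can be carried over. All the same, three different chains leave this assay at the limit, so no direction is expected, and the estimated change is a step that the limit leaves unreadable from compound 3 to compound 4. The value most likely to be reported is the same limit. For compound 4 the estimate is 3000 nM, with an expected range from 1000 nM to 30000 nM.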

Compound 4, half-maximal cytotoxic concentration: > 1000 nM
Compound 4 was reported as a limit (the forecaster's own chance of this, stated with the estimate: 90%); the middle value lies beyond the limit too.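

Compound 4 joins compounds 1, 2 and 3 as a limit, and no step among the four can be read in this assay: the limit of > 1000 nM in this assay, at which 4 of the 4 values shown sit.

The compounds shown leave open the actual half-maximal cytotoxic concentration of each compound and whether these side chains differ at all.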